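Bromo to Hydroxy on a Hydrazone Series in Fibroblast Cytotoxicity

A few compounds are considered here, and "the series" means these few. Any claim that something is new, unique, unknown or untested is made for them only; others in the source may bear on it.

Three compounds sharing one core were tested in an ADME assay on NIH3T3 cells (Mus musculus) for cytotoxicity, read by XTT assay, with a stated time of 24 h; a lower number here means a stronger inhibitor, a higher number a weaker inhibitor. Compound 1 `Cn1nnnc1SCC(=O)N/N=C/c1ccc(Br)cc1` gives 10000000 nM. Compound 2 `Cn1nnnc1SCC(=O)N/N=C/c1ccc(O)cc1` gives 632000 nM, and the change between them, hydroxy in place of bromo on an aromatic carbon, (hydroxy in place of bromo on an aromatic carbon), made a step of a 16-fold lower number from compound 1 to compound 2 (1.20 log units; beyond the scatter). Compound 3 `Cn1nnnc1SCC(=O)N/N=C/c1cccc(Br)c1` gives 316000 nM; how its core differs from that of compound 1 is not broken down here, and its value stands within the scatter of compound 2.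

Compound 4 `Cn1nnnc1SCC(=O)N/N=C/c1cccc(O)c1` is not yet measured in this assay. It carries the same kind of change as compound 2 does, (hydroxy in place of bromo on an aromatic carbon), but the place differs: meta to a large group rather than para to a large group. He expects a smaller step than the one from compound 1 to compound 2, because that step a 16-fold lower number from compound 1 to compound 2 (1.20 log units; beyond the scatter) started from a compound far weaker than compound 3, and compound 3 already stands lowest. For compound 4 he estimates 125000 nM, between 25000 nM and 400000 nM, which means an expected step of a 2.5-fold lower number from compound 3 to compound 4 (0.40 log units; beyond the scatter).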

Compound 4, half-maximal inhibitory concentration: 3160000 nM
For compound 4 the middle estimate is 25-fold (1.40 log units) below the measured one, and the stated range ends below it.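

With the hydroxy group meta to a large group, hydroxy in place of bromo gave a 10-fold higher number from compound 3 to compound 4 (1.00 log units; beyond the scatter) in this assay. Set beside the earlier step, the change did not carry over from one core to the other in size or even in direction, and the gap between the two steps lies beyond the scatter: the same change on two cores in this assay, a 16-fold lower number (1.20 log units; beyond the scatter) from compound 1 to compound 2 and a 10-fold higher number (1.00 log units; beyond the scatter) from compound 3 to compound 4, 160-fold (2.20 log units) apart, beyond the scatter of two such steps. This shows that, among these compounds, the outcome of the change on the core of compound 1 does not predict its outcome on the core of compound 3, but with only one pair on each core it does not show why the steps part, and it gives no rule for any further core.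

The compounds shown carry only bromo or hydroxy on the aromatic ring, so they leave open how an amine, a methoxy group or a carboxylic acid would behave there. From the compounds shown here alone, whether chloro or fluoro in place of bromo would split the same way also remains open.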